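The compounds below may be only part of what the source reports. "The series", "measured", "known", "first", "only" and "open" are said of these compounds alone.

Compound 1 `O=C(C1CCN(c2ccncn2)CC1)N1N=CC[C@H]1c1ccccc1`: 3.3 h
Compound 2 `CC(C)(C)C(=O)N1CCC1c1ccccc1`: > 2.75 h

Among the measured compounds shown here, in an ADME assay on cells (Hepatocyte, Homo sapiens) for metabolic stability (on this read-out lower numbers stand for a shorter-lived compound and higher numbers for a longer-lived compound), compound 1 gives 3.3 h, the only true number so far. Compound 2 stands at > 2.75 h, which is a limit of the assay and not a number.

Compound 3 `O=C(C1CCN(c2ccccn2)CC1)N1N=CC[C@H]1c1ccccc1` keeps the core of compound 1 and changes one group: pyridin-2-yl in place of pyrimidin-4-yl on an amine nitrogen in a ring. Pyridin-2-yl takes the place of pyrimidin-4-yl on an amine nitrogen in a ring. For the measured compounds named here, no measured pair of compounds shows what this swap does, so the expectation rests on compound 1 at 3.3 h. The expected step of a 1.3-fold lower number from compound 1 to compound 3 (0.12 log units; within the scatter) in this assay leans slightly towards a shorter half-life but stays within the usual scatter. Compound 3 is expected to show a half-life of 2.5 h. The estimated range for compound 3 runs from 1.2 h to 5 h.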

Compound 3, half-life: > 3.11 h
Compound 3: only a limit was reported; the forecaster's own chance of this, stated with the estimate: 25%; at least 1.2-fold (0.09 log units) between middle value and limit.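

In this assay, among the compounds shown here, compound 3 gives > 3.11 h, which is a limit of the assay and not a number, so no step from compound 1 to compound 3 can be read. The compounds shown leave open what pyridin-2-yl in place of pyrimidin-4-yl does to the half-life.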